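Biaryl cyclohexyl carbamates: methyl to fluoro

The source may hold more compounds than are shown below. What is called first, only, known or untested is meant among the compounds shown, and "the series" means these compounds.

Among the compounds with values here, compound 2 `Cc1cccc(-c2cccc(OC(=O)NC3CCCCC3)c2)c1` gives 61.8 nM in an assay on cell membranes for binding affinity to Fatty-acid amide hydrolase 1 (Rattus norvegicus) (a higher number here means a weaker inhibitor, a lower number a stronger inhibitor), the lowest of the two numbers so far, while compound 1 `Cc1ccc(-c2cccc(OC(=O)NC3CCCCC3)c2)cc1` gives 155 nM. The step of a 2.5-fold lower number from compound 1 to compound 2 (0.40 log units; beyond the scatter) is the only measured one and concerns where the methyl sits, not the group itself. Compound 3 `O=C(NC1CCCCC1)Oc1cccc(-c2cccc(F)c2)c1` differs from compound 2 by fluoro in place of methyl on an aromatic carbon. Within the data shown here, no measured step bears on exchanging the group at that place, so the expectation rests on compound 2 alone. Compound 3 is therefore expected to show a step of a 1.3-fold higher number from compound 2 to compound 3 (0.11 log units; within the scatter), not beyond the scatter. Compound 3 is estimated at 80 nM, in the range 30 nM to 250 nM.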

Compound 3, half-maximal inhibitory concentration: 96.6 nM
Beside the measured number, compound 3's estimate is 1.2-fold (0.08 log units) below it; measured number inside the range.
By their numbers in this assay, from the lowest: compounds 2, 3 and 1 (each within the scatter of the next, the first and the last beyond it).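

Exchanging the group itself, fluoro in place of methyl, gives a 1.6-fold higher number from compound 2 to compound 3 (0.19 log units; within the scatter) in this assay and so leaves the number within the scatter at this place. With a 1.6-fold lower number from compound 1 to compound 3 (0.21 log units; within the scatter) also within the scatter, compound 3 cannot be told apart from compound 1 or compound 2, even though those two are separated beyond the scatter. No supporting measurement accounts for these numbers.

Open, from the compounds shown here alone, is whether an amine, a carboxylic acid or a methoxy group at this place would shift the number beyond the scatter. Also open, going by these compounds, is whether fluoro depends on its place as methyl does.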